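A large rise expected for compound 4

The source may hold more compounds than are shown below. What is called first, only, known or untested is meant among the compounds shown, and "the series" means these compounds.

In an ADME assay on microsomes from liver (Mus musculus) for metabolic stability, read by LC-MS, with a stated time of 10 min, tested at 0.5 uM (on this read-out lower numbers stand for a less stable compound and higher numbers for a more stable compound), compound 3 (`c1ccc2c(c1)CN[C@@H](CN(CCCN1CCN(C3CC3)CC1)[C@H]1CCCc3cccnc31)C2`) stands lowest at 3% remaining, while compound 2 (`CCN1CCN(CCCN(C[C@H]2Cc3ccccc3CN2)[C@H]2CCCc3cccnc32)CC1`) gives 19% remaining and compound 1 (`c1ccc2c(c1)CN[C@@H](CN(CCCN1CCNCC1)[C@H]1CCCc3cccnc31)C2`) gives 92% remaining. Compound 4 (`c1ccc2c(c1)CN[C@@H](CN(CC[C@H]1CCCNC1)[C@H]1CCCc3cccnc31)C2`) has not been measured yet. The change from compound 3 (piperidin-3-yl in place of (4-cyclopropylpiperazin-1-yl)methyl on a saturated chain carbon, two bonds along the chain from an amine nitrogen) puts piperidin-3-yl in place of (4-cyclopropylpiperazin-1-yl)methyl on a saturated chain carbon, two bonds along the chain from an amine nitrogen.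

Within the data shown here, no measured step makes this exact swap, but three steps bear on it. Swapping a hydrogen for cyclopropyl gave a number 89 percentage points lower from compound 1 to compound 3 (beyond the scatter) and swapping it for ethyl gave a number 73 percentage points lower from compound 1 to compound 2 (beyond the scatter) so both steps were large. Cyclopropyl in place of ethyl gave a number 16 percentage points lower from compound 2 to compound 3 (beyond the scatter) and so only a modest step. Compound 4 loses the cyclopropyl and keeps a hydrogen on the amine nitrogen of its new ring, like compound 1 at 92% remaining. A large upward step is therefore expected in this assay and the estimated step is a number 62 percentage points higher from compound 3 to compound 4 (beyond the scatter) on this reasoning. Among the measured compounds shown here, no measured compound carries piperidin-3-yl, so the range stays wide. For compound 4 the estimated value is 65% remaining, with an expected range from 30% to 95% remaining.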

Compound 4, percent of the compound remaining: 56%
Compound 4: the middle estimate sits 9 percentage points above what was measured; measured number inside the range.
By their numbers in this assay, from the lowest: compound 3; then compound 2; then compound 4; then compound 1.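

In this assay the change to piperidin-3-yl gives a number 53 percentage points higher from compound 3 to compound 4 (beyond the scatter) and a number 37 percentage points higher from compound 2 to compound 4 (beyond the scatter) so a ring with a hydrogen on its amine nitrogen again stands well above the two compounds that carry a group on that nitrogen. The same change gives a number 36 percentage points lower from compound 1 to compound 4 (beyond the scatter) and this is the new point: a hydrogen on the ring nitrogen does not by itself match compound 1, so the identity of the ring at this place on the saturated chain also matters, and the size of that step is large. No measurement here explains why the ring change moves the number in either direction.

From the compounds shown here alone, it remains open whether ethyl or cyclopropyl on the nitrogen of piperidin-3-yl would lower the number as sharply as those groups do on the piperazine ring, and whether the opposite arrangement at the defined stereocentre of piperidin-3-yl would give a similar result. Going by these compounds, how a morpholine ring or a longer chain at this place would behave also stays unknown.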